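The source may report more compounds than this note shows. Statements on the series, on what has been measured and on what is new or still open speak of the compounds shown alone.

Of the compounds shown here, three sharing one core have been tested in a functional assay on MDA-MB-231 cells (Homo sapiens) for inhibition, read by CCK-8 assay, with a stated time of 48 h; a higher number here means a weaker inhibitor of growth, a lower number a stronger inhibitor of growth. Compound 1 `CN1CCN(c2ccc(Nc3ncc(Cl)c(NCc4ccccc4)n3)nc2)CC1` gives 24800 nM, compound 2 `CN1CCN(c2ccc(Nc3ncc(Cl)c(NCc4ccc(C(F)(F)F)cc4)n3)nc2)CC1` gives 19100 nM, and compound 3 `COc1cccc(CNc2nc(Nc3ccc(N4CCN(C)CC4)cn3)ncc2Cl)c1` gives 20300 nM. Compound 3 thus lies within the usual scatter of both others. The next structure, compound 4 `Cc1cccc(Nc2nc(Nc3ccc(N4CCN(C)CC4)cn3)ncc2Cl)c1`, differs from it as follows: 3-methylphenyl in place of 3-methoxybenzyl on a nitrogen on an aromatic ring. Put simply, 3-methylphenyl takes the place of 3-methoxybenzyl on a nitrogen on an aromatic ring.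

The measured steps bear on this only in part. Adding trifluoromethyl gave a 1.3-fold lower number from compound 1 to compound 2 (0.11 log units; within the scatter), adding methoxy gave a 1.2-fold lower number from compound 1 to compound 3 (0.09 log units; within the scatter), and exchanging one aromatic group for the other gave a 1.1-fold higher number from compound 2 to compound 3 (0.03 log units; within the scatter). Going by these compounds, all three steps changed a group on the aromatic ring, and none removed the saturated chain carbon bound to the nitrogen, so that part of the change is untested. With real uncertainty, the step therefore expected is small and not clearly beyond the scatter and is estimated as a 1.5-fold lower number from compound 3 to compound 4 (0.16 log units; within the scatter). For compound 4 the estimated value is 14000 nM, with an expected range from 4000 nM to 35000 nM.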

Compound 4, concentration for 50% growth inhibition: 5270 nM
Estimate against measurement, compound 4: 2.7-fold (0.42 log units) above, and the stated range covers the measured number.
By their numbers in this assay, from the lowest: compound 4; then compounds 2, 3 and 1 (each within the scatter of the next).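

On a nitrogen on an aromatic ring, swapping the benzyl-type group for 3-methylphenyl produces changes beyond the scatter in this assay: a 3.9-fold lower number from compound 3 to compound 4 (0.59 log units; beyond the scatter), a 3.6-fold lower number from compound 2 to compound 4 (0.56 log units; beyond the scatter) and a 4.7-fold lower number from compound 1 to compound 4 (0.67 log units; beyond the scatter). The earlier steps shown here, which altered only groups on the benzyl ring, all stayed within the scatter, so this position responds to a change that removes the saturated chain carbon and puts the ring directly on the nitrogen, although each step is only modest. No measurement shown here accounts for this difference.

This single change also brings in the methyl group, so the compounds shown leave open how much of the step belongs to the lost chain carbon and how much to the methyl. A plain phenyl or a 3-methoxyphenyl on this nitrogen would separate the two, and a longer chain such as 2-phenylethyl would extend the comparison in the other direction.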